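This account rests on a few compounds, and the source may have more. Where it says the series, first, only, none or still open, it means among the compounds named here.

Measured compounds:
compound 1 `COc1ccc(-c2cc(/C=C/C(=O)c3ccc(N)cc3)[nH]n2)cc1` gives 1320 nM
compound 2 `COc1cc(-c2cc(/C=C/C(=O)c3ccc(N)cc3)[nH]n2)cc(OC)c1OC` gives 550 nM

In a functional assay on CCRF-CEM cells (Homo sapiens) for inhibition, read by sulforhodamine B assay, with a stated time of 48 h (on this read-out lower numbers stand for stronger inhibition of growth and higher numbers for weaker inhibition of growth), compound 2 has the lowest of the two numbers; the nearest is compound 1, which returns a higher number, a gap that lies beyond the usual scatter. Compound 3 `COc1cc(-c2cc(/C=C/C(=O)c3ccc(Cl)c(Cl)c3)[nH]n2)cc(OC)c1OC` has not yet been measured in this assay. It differs from compound 2 in one place: 3,4-dichlorophenyl in place of 4-aminophenyl on a carbonyl carbon. No step of this kind between two measured compounds is available here, so the direction of this change on this read-out cannot be taken from any shown pair. The step of a 1.1-fold higher number from compound 2 to compound 3 (0.04 log units; within the scatter) is therefore expected to be small, of a size that need not rise beyond the scatter. Compound 3 is estimated at 600 nM, with a range from 200 nM to 2000 nM, a wide range reflecting the absence of any measured pair carrying this change.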

Compound 3, concentration for 50% growth inhibition: 2150 nM
Estimate against measurement, compound 3: 3.6-fold (0.55 log units) below; measured number above the stated range.
By their numbers in this assay, from the lowest: compound 2; then compounds 1 and 3 (each within the scatter of the next).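

In this assay, placing 3,4-dichlorophenyl in place of 4-aminophenyl on a carbonyl carbon gives a 3.9-fold higher number from compound 2 to compound 3 (0.59 log units; beyond the scatter), the first step shown at this position. It shows that the group on the carbonyl carbon matters to growth inhibition, which is weaker with 3,4-dichlorophenyl than with 4-aminophenyl in this pair, a change that also takes the count from 1 hydrogen-bond donor and 1 acceptor to none. No measurement available here explains the rise in the number.

On these data alone, it remains open whether the shift follows from losing the amine or from gaining the two chlorines, which a plain phenyl, a 4-chlorophenyl or a 4-hydroxyphenyl on the same carbon would help to separate. As far as these compounds go, it is also open whether the same change would move compound 1 in the same direction.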